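Swapping Methoxy for Cyano on the Fused Ring

The source may report more compounds than this note shows. Statements on the series, on what has been measured and on what is new or still open speak of the compounds shown alone.

Of the compounds shown here, two have been measured so far. Compound 1 `c1cncc(-c2nc3ccccc3n2C2CC2)c1` carries a hydrogen at the position in question, and in an assay on V79 cells for inhibition of cytochrome P450 11B1, mitochondrial (Homo sapiens), read by HTRF, with a stated time of 1 h (on this read-out lower numbers stand for stronger inhibition and higher numbers for weaker inhibition), compound 1 gives only a limit of the assay, > 8330 nM. Compound 2 `COc1ccc2nc(-c3cccnc3)n(C3CC3)c2c1` carries a methoxy group instead, and in this assay compound 2 gives 1980 nM. Among the measured compounds shown here, the single measured step is an at least 4.2-fold lower number from compound 1 to compound 2 (0.62 log units; beyond the scatter). Compound 2 thus holds the only actual number shown; the other value is a limit, as stated for (the limit of > 8330 nM in this assay, at which 1 of the 2 values shown sits).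

Compound 3 `N#Cc1ccc2nc(-c3cccnc3)n(C3CC3)c2c1` differs from compound 2 in one place: cyano in place of methoxy on an aromatic carbon. For the measured compounds named here, the only measured step shows that adding a group on this carbon lowered the number, but it does not compare two different groups at that carbon, so it bears on the new change only loosely. With nothing to point either way, the step is expected to be small, amounting to a 1.3-fold lower number from compound 2 to compound 3 (0.12 log units; within the scatter). Compound 3 is therefore expected to give about 1500 nM, with a range from 300 nM to 8000 nM.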

Compound 3, half-maximal inhibitory concentration: 374 nM
Beside the measured number, compound 3's estimate is 4.0-fold (0.60 log units) above it; low and high end bracket the measured number.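

Among the compounds shown here, the earlier compounds showed only that a methoxy group on this aromatic carbon gave a lower number than hydrogen; now two groups can be compared at the same carbon, and in this assay the identity of the group clearly matters, with a 5.3-fold lower number from compound 2 to compound 3 (0.72 log units; beyond the scatter) when cyano replaces methoxy. The two groups match in heavy atoms and in hydrogen-bond acceptors as counted, so those counts alone do not separate compound 2 from compound 3. Measured against hydrogen, cyano gives an at least 22-fold lower number from compound 1 to compound 3 (1.34 log units; beyond the scatter), and this size is only a minimum because compound 1 gives a limit rather than a number: the limit of > 8330 nM in this assay, at which 1 of the 3 values shown sits.

Only hydrogen, methoxy and cyano are shown on this carbon, so it remains open how an amine, a carboxylic acid, a chlorine atom or a longer chain would compare with cyano. Also open, on these data alone, is whether cyano would give a similar step on another carbon of the shared core, and how these compounds behave against any other enzyme.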